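A few compounds are considered here, and "the series" means these few. Any claim that something is new, unique, unknown or untested is made for them only; others in the source may bear on it.

Measured compounds:
Compound 1 `CN1CCN(CCC(=O)OC2CC3(N4CCCC4)CC(c4ccccc4)C2C(c2ccccc2)C3)CC1` gives 21300 nM in an ADME assay on L6 cells (Rattus norvegicus) for cytotoxicity; a higher number here means a weaker inhibitor, a lower number a stronger inhibitor.
Compound 2 `CN1CCN(CCCN2CCC3(N4CCCCC4)CC(c4ccccc4)C2C(c2ccccc2)C3)CC1` gives 62500 nM.
Compound 3 `CN1CCN(CCC(=O)OC2CC3(N4CCCCC4)CC(c4ccccc4)C2C(c2ccccc2)C3)CC1` gives 23500 nM.

Compound 2 returns the highest number of the three, and its gaps to compound 3 and to compound 1 both lie beyond the usual scatter, so it is the weakest inhibitor among the measured set. Compound 3 and compound 1 share one core and differ in a single place: pyrrolidin-1-yl in place of piperidin-1-yl on a saturated ring carbon. That change made a step of a 1.1-fold lower number from compound 3 to compound 1 (0.04 log units; within the scatter), which is within the scatter, so the two esters cannot be ordered against each other.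

Compound 4 `CN1CCN(CCCN2CCC3(N4CCCC4)CC(c4ccccc4)C2C(c2ccccc2)C3)CC1` is not yet measured. It stands to compound 2 as compound 1 stands to compound 3: pyrrolidin-1-yl in place of piperidin-1-yl on a saturated ring carbon. This is the same kind of change, but the surroundings are not identical. In compound 3 one of the ring atoms two ring bonds away bears a ((2-(4-methylpiperazin-1-yl)ethyl)carbonyl)oxy group, whereas in compound 2 the two ring atoms two ring bonds away each bear a phenyl group. How the core of compound 2 differs from the core of compound 3 is not broken down here.

Compound 4 is expected to show a step of a 1.1-fold lower number from compound 2 to compound 4 (0.03 log units; within the scatter), close to the earlier one, because a 1.1-fold lower number from compound 3 to compound 1 (0.04 log units; within the scatter) stayed within the scatter. Compound 4 is therefore estimated at 58000 nM, with a likely range from 25000 nM to 130000 nM.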

Compound 4, half-maximal inhibitory concentration: 27500 nM
Estimate against measurement, compound 4: 2.1-fold (0.32 log units) above, and the stated range covers the measured number.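

In this assay, putting pyrrolidin-1-yl in place of piperidin-1-yl on a saturated ring carbon gave a 2.3-fold lower number from compound 2 to compound 4 (0.36 log units; beyond the scatter), a step that on its own can be read as real. Set beside the earlier step for the same change, it cannot be separated from it: the same change on two cores in this assay, a 1.1-fold lower number (0.04 log units; within the scatter) from compound 3 to compound 1 and a 2.3-fold lower number (0.36 log units; beyond the scatter) from compound 2 to compound 4, 2.1-fold (0.31 log units) apart, within the scatter of two such steps This shows that the two cores give no measurable disagreement on this change, so a single shared step size remains possible, but it does not show that the step is the same on both cores, since one step lies beyond the scatter and the other within it, and two pairs are too few to establish a rule for the series.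

The compounds shown leave open how other groups on that saturated ring carbon, such as dimethylamino or morpholin-4-yl, would compare with pyrrolidin-1-yl and piperidin-1-yl on either core. They also leave open whether the step would hold on a core with a longer chain leading to the 4-methylpiperazin-1-yl group, or with a carboxylic acid in place of that amine.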